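Replacing allyl with methoxycarbonyl in an inactive compound

This account rests on a few compounds, and the source may have more. Where it says the series, first, only, none or still open, it means among the compounds named here.

Compound 1 `C=CCOC1=CC(=O)S[C@]1(C)CCCCCC`: > 50 ug/mL
Compound 2 `C=CCOC1=CC(=O)S[C@]1(C)CCCCCCCC`: > 50 ug/mL
Compound 3 `CCCCCC[C@@]1(C)SC(=O)C=C1OCC(=O)NCC(=O)O`: 6.6 ug/mL

In a functional assay on MCF7 cells (Homo sapiens) for inhibition (a lower number here means a stronger inhibitor, a higher number a weaker inhibitor), compound 2 gives only a limit (> 50 ug/mL). Compound 4 `CCCCCCCC[C@@]1(C)SC(=O)C=C1OC(=O)OC` carries methoxycarbonyl in place of allyl on an oxygen on an unsaturated carbon. The chain step (a step that the two limits leave unreadable from compound 1 to compound 2) offers no usable size. The more relevant step also alters the group on that oxygen (an at least 7.5-fold lower number from compound 1 to compound 3 (0.87 log units; beyond the scatter)), but its entering group differs from methoxycarbonyl, so it guides only loosely. A smaller step towards a lower number is therefore expected in this assay (an at least 1.6-fold lower number from compound 2 to compound 4 (0.22 log units; that floor lies within the scatter)). For compound 4 the estimated value is 30 ug/mL (expected range 10 ug/mL to 60 ug/mL).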

Compound 4, half-maximal inhibitory concentration: 10.7 ug/mL
Estimate against measurement, compound 4: 2.8-fold (0.45 log units) above; low and high end bracket the measured number.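

In this assay, putting methoxycarbonyl in place of allyl on this oxygen gives an at least 4.6-fold lower number from compound 2 to compound 4 (0.66 log units; beyond the scatter). A lower number at this position is therefore not tied to the (carboxymethyl)carbamoyl-bearing group of compound 3, since a second, different group with no net charge also reaches one. Compound 2 is recorded only as a limit, so this step gives a minimum size and not a full one: the limit of > 50 ug/mL in this assay, at which 2 of the 4 values shown sit.

Going by these compounds, whether a simpler acetyl group or a plain carboxylic acid on this oxygen would also lower the number remains open. So does whether methoxycarbonyl would give a similar step on the shorter-chain core of compound 1.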